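From 4-methylphenyl to 2,4,6-trimethylphenyl in the series

The source may hold more compounds than are shown below. What is called first, only, known or untested is meant among the compounds shown, and "the series" means these compounds.

Of the compounds shown here, two have numbers so far in a functional assay on HCT-116 cells (Homo sapiens) for inhibition, read by MTT assay, with a stated time of 48 h; a lower number here means a stronger inhibitor, a higher number a weaker inhibitor. Compound 1 (`COc1ccc(/C=C2\SC(=O)N(CCNC(=O)Nc3c(C)n(C)n(-c4ccccc4)c3=O)C2=O)cc1`) gives 3160 nM. Compound 2 (`Cc1ccc(/C=C2\SC(=O)N(CC(=O)Nc3c(C)n(C)n(-c4ccccc4)c3=O)C2=O)cc1`) gives 47700 nM, the higher number of the two and so the weaker inhibitor, with a gap beyond the scatter. These two compounds differ in more than one place, so their gap cannot be assigned to any single group.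

Compound 3 (`Cc1cc(C)c(/C=C2\SC(=O)N(CC(=O)Nc3c(C)n(C)n(-c4ccccc4)c3=O)C2=O)c(C)c1`) has not yet been measured. It has 2,4,6-trimethylphenyl in place of 4-methylphenyl on a double-bonded chain carbon bound to a double-bonded ring carbon, and the rest of compound 2 is unchanged: 2,4,6-trimethylphenyl in place of 4-methylphenyl on a double-bonded chain carbon bound to a double-bonded ring carbon. For the measured compounds named here, no measured pair shows what a change at this place does. The expectation in this assay therefore starts from compound 2 at 47700 nM, and no step beyond the scatter is expected in either direction. The estimated step is a 1.2-fold lower number from compound 2 to compound 3 (0.08 log units; within the scatter). For compound 3 the estimated value is 40000 nM, with an expected range from 13000 nM to 100000 nM.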

Compound 3, half-maximal inhibitory concentration: 56200 nM
Compound 3: the middle estimate sits 1.4-fold (0.15 log units) below what was measured, and the stated range covers the measured number.
By their numbers in this assay, from the lowest: compound 1; then compounds 2 and 3 (each within the scatter of the next).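

In this assay, for the compounds shown here, the exchange of 4-methylphenyl for 2,4,6-trimethylphenyl on a double-bonded chain carbon bound to a double-bonded ring carbon gives a 1.2-fold higher number from compound 2 to compound 3 (0.07 log units; within the scatter) and is the first single change that can be read. At this place, then, a phenyl group with 9 heavy atoms in place of 7, all of them carbon, and with no hydrogen-bond donors or acceptors on either group, gives no step beyond the scatter, so the two extra methyl groups do not separate compound 3 from compound 2 in this read-out. No measured property bears on this result, so nothing can be stated about what lies behind it.

Whether a phenyl group carrying an amine or a carboxylic acid at this place would give a step beyond the scatter remains open, since the groups shown here are carbon only. Going by these compounds alone, the gap between compound 1 and compound 2 also remains unassigned, as those two compounds differ in more than one place and no single-change step yet connects them.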